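A 4-chlorophenyl Replaces the 2,3-dihydro-1H-inden-5-yl Group

The compounds below may be only part of what the source reports. "The series", "measured", "known", "first", "only" and "open" are said of these compounds alone.

Of the compounds shown here, three have been measured so far. Compound 1 `O=C(O)CCNC(=O)c1ccc(CN(c2ccc3c(c2)CCC3)c2nc(-c3ccc(C(F)(F)F)cc3)cs2)cc1` was tested in an in vitro assay on BHK cells for displacement of a labelled ligand from gastric inhibitory polypeptide receptor (Homo sapiens), read by scintillation proximity assay (on this read-out higher numbers stand for weaker inhibition and lower numbers for stronger inhibition), where compound 1 gives 1100 nM. Compound 2 `O=C(O)CCNC(=O)c1ccc(CN(c2ccc3c(c2)CCCC3)c2nc(-c3ccc(Cl)c(Cl)c3)cs2)cc1` gives 830 nM in this assay, and compound 3 `O=C(O)CCNC(=O)c1ccc(CN(c2ccc(C3=CCCCC3)cc2)c2nc(-c3ccc(Cl)cc3)c(-c3ccccc3)s2)cc1` gives 1000 nM. Compound 1 shows the highest number of the three, but its gaps to compound 3 and to compound 2 both lie within the usual scatter, so no ranking can be drawn. Compound 4 `O=C(O)CCNC(=O)c1ccc(CN(c2ccc(Cl)cc2)c2nc(-c3ccc(C(F)(F)F)cc3)cs2)cc1` has not yet been measured. It differs from compound 1 in one place: 4-chlorophenyl in place of 2,3-dihydro-1H-inden-5-yl on a nitrogen on an aromatic ring. Among the measured compounds shown here, no step of this kind between measured compounds exists, so nothing supports expecting a change beyond the scatter in either direction. Compound 4 is therefore expected to give 1300 nM in this assay, within a range from 500 nM to 3500 nM. The expected step is a 1.2-fold higher number from compound 1 to compound 4 (0.07 log units; within the scatter), small in either direction.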

Compound 4, half-maximal inhibitory concentration: 649 nM
For compound 4 the middle estimate is 2.0-fold (0.30 log units) above the measured one; the measured number falls inside the stated range.
By their numbers in this assay, from the lowest: compounds 4, 2, 3 and 1 (each within the scatter of the next).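

In this assay, the first step read at this position is a 1.7-fold lower number from compound 1 to compound 4 (0.23 log units; within the scatter), so 2,3-dihydro-1H-inden-5-yl and 4-chlorophenyl cannot be told apart on this read-out. In this pair, the five-membered non-aromatic ring of carbon is therefore not needed for a number of this size. Nothing measured speaks to the reason for this result.

Going by these compounds, it remains open whether the chlorine itself matters, and whether a plain phenyl, a 4-methoxyphenyl or a cyclohexyl group on this nitrogen would give a similar number.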